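The compounds below may be only part of what the source reports. "The series", "measured", "known", "first", "only" and "open" are said of these compounds alone.

Compound 1 `O=C(Nc1cccc(C(F)(F)F)c1)N[C@H]1CC[C@H](Oc2cccc(C(F)(F)F)c2)CC1` gives 1050 nM
Compound 2 `O=C(Nc1cccc(C(F)(F)F)c1)N[C@H]1CC[C@@H](Oc2ccc(F)cc2)CC1` gives 6000 nM

In a functional assay on CRL2813 cells (Homo sapiens) for antiproliferative activity, read by sulforhodamine B assay, with a stated time of 3 days, in the presence of a further agent that is not named here (a higher number here means a weaker inhibitor, a lower number a stronger inhibitor), compound 1 has the lower of the two numbers (1050 nM), which makes it the stronger inhibitor of the pair. Compound 3 `O=C(Nc1cccc(C(F)(F)F)c1)N[C@H]1CC[C@H](Oc2ccccc2F)CC1` has 2-fluorophenyl in place of 3-(trifluoromethyl)phenyl on an oxygen on a saturated carbon. Among the compounds with values here, no measured step shows this change directly. Compound 2, which also has a fluorophenyl group, gives a higher number (6000 nM), so a moderate rise, meaning weaker inhibition, is expected. The estimated step is a 3.3-fold higher number from compound 1 to compound 3 (0.52 log units; beyond the scatter) in size. For compound 3 the expected value is 3500 nM, within an estimated range from 1200 nM to 10000 nM.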

Compound 3, half-maximal inhibitory concentration: 2800 nM
Estimate against measurement, compound 3: 1.3-fold (0.10 log units) above, within the range that was stated.
By their numbers in this assay, from the lowest: compound 1; then compound 3; then compound 2.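

In this assay, within the data shown here, putting 2-fluorophenyl in place of 3-(trifluoromethyl)phenyl on an oxygen on a saturated carbon gives a 2.7-fold higher number from compound 1 to compound 3 (0.43 log units; beyond the scatter), the only direct reading of a change at this position. The step is modest but beyond the scatter, so the group carried here does affect the number, and a smaller fluorinated aryl group still leaves measurable antiproliferative activity. Nothing shown accounts for the step. The compounds leave open how a plain phenyl, an amine, a carboxylic acid or a longer chain would read on this oxygen.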